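This account rests on a few compounds, and the source may have more. Where it says the series, first, only, none or still open, it means among the compounds named here.

Among the measured compounds shown here, compound 3 `COc1ccc(N2C(=O)C(c3cn(C)c4ccccc34)=C(c3nn(CCCN4CCCCC4)c4ncccc34)C2=O)cc1` is the one member of this set with a measured number: in a functional assay on KB cells (Homo sapiens) for antiproliferative activity, read by MTT assay, with a stated time of 48 h (a higher number here means a weaker inhibitor, a lower number a stronger inhibitor), compound 3 gives 44000 nM. Its two relatives carry only a limit. Compound 1 `CN(C)CCCn1nc(C2=C(c3cn(C)c4ccccc34)C(=O)NC2=O)c2cccnc21` reaches no measurable effect, as in this assay compound 1 gives > 100000 nM, a limit of the assay rather than a number. Compound 2 `CN1CCN(CCCn2nc(C3=C(c4cn(C)c5ccccc45)C(=O)NC3=O)c3cccnc32)CC1` likewise gives > 100000 nM in this assay, again a limit. For the measured compounds named here, both of those values are limits, so the one single-place step, a step that the two limits leave unreadable from compound 1 to compound 2, cannot be read. Compound 4 `Cn1cc(C2=C(c3nn(CCCN4CCCCC4)c4ncccc34)C(=O)NC2=O)c2ccccc21` differs from compound 3 by hydrogen in place of 4-methoxyphenyl on an amide-type nitrogen in a ring. Going by the values given here, no measured step mirrors this change. Among the compounds with values here, what the numbers do show is that (the limit of > 100000 nM in this assay, at which 2 of the 3 values shown sit), and both of those compounds carry the hydrogen that enters in compound 4, while compound 3, with the 4-methoxyphenyl, is the one that gives a number. The step of a 2.7-fold higher number from compound 3 to compound 4 (0.44 log units; beyond the scatter) is therefore expected to weaken inhibition, most likely to the limit. Compound 4 is estimated at 120000 nM, between 40000 nM and 300000 nM.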

Compound 4, half-maximal inhibitory concentration: 98000 nM
For compound 4 the middle estimate is 1.2-fold (0.09 log units) above the measured one; measured number inside the range.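

In this assay the amide-type nitrogen in the five-membered ring now has a direct reading: hydrogen in place of 4-methoxyphenyl gives a 2.2-fold higher number from compound 3 to compound 4 (0.35 log units; beyond the scatter), a modest loss. The 4-methoxyphenyl is therefore not needed for a measurable number, since compound 4 gives 98000 nM, a true value and not a limit. With hydrogen on that nitrogen, piperidin-1-yl at the chain end shows no clear gain over the other two amines, as the comparisons an at least 1.0-fold lower number from compound 2 to compound 4 (0.00 log units; that floor lies within the scatter) and an at least 1.0-fold lower number from compound 1 to compound 4 (0.00 log units; that floor lies within the scatter) each start from a limit of the assay.

Going by these compounds, it remains open whether the step comes from the aromatic ring or its methoxy group, which a plain phenyl or a methyl on that nitrogen could help to separate. On these data alone, how morpholin-4-yl or a longer chain would read also remains open.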